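This account rests on a few compounds, and the source may have more. Where it says the series, first, only, none or still open, it means among the compounds named here.

Compound 1 `Brc1cn2ccnc2c(-c2ccc3ncn(C4CCCCC4)c3c2)n1`: 5.58% in a functional assay on RXF 393 cells (Homo sapiens) for inhibition, read by sulforhodamine B assay, with a stated time of 48 h, tested at 10 uM; on this read-out higher numbers stand for more inhibition at the one concentration tested (going by the name of the read-out) and lower numbers for less inhibition
Compound 2 `c1ccc(-c2cn3ccnc3c(-c3ccc4ncn(C5CCCCC5)c4c3)n2)cc1`: 45%
Compound 3 `COc1ccc(-c2cn3ccnc3c(-c3ccc4ncn(C5CCCCC5)c4c3)n2)cc1`: -8.48%

Compound 3 stands lowest of the three numbers. Its nearest neighbour is compound 1, and the step of a number 14.1 percentage points lower from compound 1 to compound 3 (beyond the scatter) lies beyond the scatter; the step of a number 53.5 percentage points lower from compound 2 to compound 3 (beyond the scatter) is larger still. Compound 4 `O=Cc1ccc(-c2cn3ccnc3c(-c3ccc4ncn(C5CCCCC5)c4c3)n2)cc1` is the next member of the series. The change is formyl in place of methoxy on an aromatic carbon.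

Among the measured compounds shown here, no measured step exchanges one group on the phenyl ring for another. The steps only show what happens when the bromo of compound 1 is replaced by a whole ring, a number 39.4 percentage points higher from compound 1 to compound 2 (beyond the scatter), and what happens when methoxy enters that ring, a number 53.5 percentage points lower from compound 2 to compound 3 (beyond the scatter). So the methoxy group goes with a large loss, while compound 1 with its small bromo also sits low. Compound 3 gives -8.48%, the lowest point, and compound 2 with its plain phenyl gives 45% far above. Whether formyl behaves like methoxy or like hydrogen is not shown by anything measured. For compound 4 an upward step of a number 20.5 percentage points higher from compound 3 to compound 4 (beyond the scatter) is expected, modest and uncertain. Compound 4 is estimated at 12%, with a range from -12% to 40%.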

Compound 4, a percentage reported as inhibition, at one concentration (the size of the read-out at that concentration, not a potency): 25%
Compound 4: middle estimate off by 13 percentage points, on the low side; measured number inside the range.
By their numbers in this assay, from the lowest: compound 3; then compound 1; then compound 4; then compound 2.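

In this assay the exchange of methoxy for formyl, para to a large group, gives a number 33.5 percentage points higher from compound 3 to compound 4 (beyond the scatter) even though the two groups match in heavy atoms and in hydrogen-bond acceptors, so this position separates groups that those counts do not. Formyl in place of hydrogen gives a number 20 percentage points lower from compound 2 to compound 4 (beyond the scatter) and leaves the plain phenyl of compound 2 highest of the four, yet this drop is smaller than the one seen with methoxy, so a group at this place need not cancel the whole gain that came with the ring. Replacing bromo with the 4-formylphenyl ring gives a number 19.4 percentage points higher from compound 1 to compound 4 (beyond the scatter) and shows that a substituted ring can stand above the bromo compound, which the methoxy-bearing ring of compound 3 does not do.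

Nothing available explains the gap between methoxy and formyl. Still open, from the compounds shown here alone, is where other groups at this place would fall relative to hydrogen, formyl and methoxy, for example an amine, a carboxylic acid or a longer chain, and whether any of them could rise above the plain phenyl of compound 2.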